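This account rests on a few compounds, and the source may have more. Where it says the series, first, only, none or still open, it means among the compounds named here.

Compound 1 `CCCC(O)CC(=O)O[C@H](CC=C(C)C)C1=CC(=O)c2c(O)ccc(O)c2C1=O` is the weakest of the three measured compounds: in a functional assay on HeLa cells (Homo sapiens) for cytotoxicity, read by MTT assay (on this read-out higher numbers stand for weaker inhibition and lower numbers for stronger inhibition), compound 1 gives 59300 nM, the highest number among them. Compound 2 `CC[C@@](C)(O)CC(=O)O[C@H](CC=C(C)C)C1=CC(=O)c2c(O)ccc(O)c2C1=O` gives 17900 nM in this assay, and compound 3 `CC(C)=CC[C@@H](OC(=O)C1CCCO1)C1=CC(=O)c2c(O)ccc(O)c2C1=O` gives 17000 nM. The steps from compound 1 to its neighbours are both modest but beyond the scatter, a 3.3-fold lower number from compound 1 to compound 2 (0.52 log units; beyond the scatter) and a 3.5-fold lower number from compound 1 to compound 3 (0.54 log units; beyond the scatter), whereas compound 2 and compound 3 lie within the scatter of each other, a 1.1-fold lower number from compound 2 to compound 3 (0.02 log units; within the scatter).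

Compound 4 `CCC(C)(O)CC(=O)O[C@H](CC=C(C)C)C1=CC(=O)c2c(O)ccc(O)c2C1=O` differs from compound 1 as follows: 1-hydroxy-1-methylpropyl in place of 1-hydroxybutyl on a saturated chain carbon bound to a carbonyl carbon. Compound 4 is the same change that turns compound 1 into compound 2, except that compound 4 carries no defined configuration at the carbon that bears the hydroxy group, while compound 2 does. Among the compounds with values here, the step of a 3.3-fold lower number from compound 1 to compound 2 (0.52 log units; beyond the scatter) is therefore the one measured step that bears directly on this change; it was modest and pointed toward a lower number. Within the data shown here, the one step from compound 2 to compound 3 offers no further guidance because a 1.1-fold lower number from compound 2 to compound 3 (0.02 log units; within the scatter) lies within the scatter.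

On this basis the account expects compound 4 to sit near compound 2, with a step of a 2.8-fold lower number from compound 1 to compound 4 (0.45 log units; beyond the scatter) from compound 1. The expected value for compound 4 in this assay is 21000 nM, with a range from 9000 nM to 50000 nM.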

Compound 4, half-maximal inhibitory concentration: 25200 nM
Estimate against measurement, compound 4: 1.2-fold (0.08 log units) below, and the stated range covers the measured number.
By their numbers in this assay, from the lowest: compounds 3, 2 and 4 (each within the scatter of the next); then compound 1.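

In this assay the 1-hydroxy-1-methylpropyl group again gives a lower number than 1-hydroxybutyl on the saturated chain carbon bound to a carbonyl carbon, now with the hydroxy-bearing carbon drawn without a configuration (a 2.4-fold lower number from compound 1 to compound 4 (0.37 log units; beyond the scatter)), so this change no longer rests on compound 2 alone. Drawing that carbon with or without a configuration produces no separable difference on this read-out (a 1.4-fold higher number from compound 2 to compound 4 (0.15 log units; within the scatter)), and the comparison can be read only with this limit in mind: the fact that one of compounds 2 and 4 is drawn with a defined configuration and the other without, at the place where they differ. Compound 4 also stays within the scatter of the ring-bearing compound 3 (a 1.5-fold higher number from compound 3 to compound 4 (0.17 log units; within the scatter)), so 2-hydroxy-2-methylbutyl and oxolan-2-yl on a carbonyl carbon are not told apart here either.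

What the opposite configuration at the hydroxy-bearing carbon gives on its own remains open, since the compounds shown do not isolate it. Also open, on these data alone, is whether an amine or a carboxylic acid in place of the hydroxy group, or a longer chain than 1-hydroxy-1-methylpropyl, would keep the number near those of compound 2, compound 3 and compound 4.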